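The source may report more compounds than this note shows. Statements on the series, on what has been measured and on what is new or still open speak of the compounds shown alone.

In a functional assay on NCI-H69 cells (Homo sapiens) for cytotoxicity, read by MTT assay, with a stated time of 3 days (a higher number here means a weaker inhibitor, a lower number a stronger inhibitor), compound 1 (`C[C@H]1O[C@@H](n2cc(F)c(NC(=O)Oc3ccc(Cl)cc3)nc2=O)[C@H](O)[C@@H]1O`) gives 90 ug/mL while compound 2 (`CCCCCOC(=O)Nc1nc(=O)n([C@@H]2O[C@H](C)[C@H]3OC(=O)O[C@H]32)cc1F`) gives 180 ug/mL and compound 3 (`CCC(C)COC(=O)Nc1nc(=O)n([C@@H]2O[C@H](C)[C@@H](O)[C@H]2O)cc1F`) gives 370 ug/mL as its value. Compound 2 thus sits within the scatter of compound 1 and, just beyond the scatter, holds a lower number than compound 3. Compound 4 (`CC(C)CCOC(=O)Nc1nc(=O)n([C@@H]2O[C@H](C)[C@H]3OC(=O)O[C@H]32)cc1F`) comes from compound 2 by one change (isopropyl in place of propyl on a saturated chain carbon, two bonds along the chain from an oxygen next to a carbonyl group) with the same atoms joined differently. Among the measured compounds shown here, the one measured step at this oxygen (a 4.1-fold higher number from compound 1 to compound 3 (0.61 log units; beyond the scatter)) is modest, but it swaps 4-chlorophenyl for 2-methylbutyl and does not address a rearranged chain. Compound 3 also holds a branched chain, yet its core differs from that of compound 2, so branching is not isolated. No step beyond the scatter is therefore expected in this assay from this change. The estimated step is small (a 1.1-fold higher number from compound 2 to compound 4 (0.05 log units; within the scatter)) and within the scatter. Compound 4 is expected at 200 ug/mL with an estimated range from 100 ug/mL to 380 ug/mL for now.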

Compound 4, half-maximal inhibitory concentration: 310 ug/mL
Beside the measured number, compound 4's estimate is 1.6-fold (0.19 log units) below it; the range from low to high includes it.
By their numbers in this assay, from the lowest: compounds 1, 2, 4 and 3 (each within the scatter of the next, the first and the last beyond it).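

In this assay, isopropyl in place of propyl on a saturated chain carbon, two bonds along the chain from an oxygen next to a carbonyl group, gives a 1.7-fold higher number from compound 2 to compound 4 (0.24 log units; within the scatter) on an unchanged core. Among the compounds shown here, this is the first step here that isolates branching, and on the core of compound 2 that rearrangement stays within the scatter. Nothing available explains the size of this step.

On these data alone, whether a longer chain such as hexyl, or a terminal amine, would move the number beyond the scatter remains open. Also open, as far as these compounds go, is whether the same branching change reads alike on the core of compound 3.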